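Varying the Sulfonyl Aryl Group in an EP3 Binding Series

A few compounds are considered here, and "the series" means these few. Any claim that something is new, unique, unknown or untested is made for them only; others in the source may bear on it.

Three compounds have been measured in an assay on isolated protein for displacement of a labelled ligand from prostaglandin E2 receptor EP3 subtype (Homo sapiens), read by scintillation counting, with a stated time of 2 h; on this read-out higher numbers stand for weaker inhibition and lower numbers for stronger inhibition:
Compound 1 `COc1ccc(Cl)cc1S(=O)(=O)NC(=O)NC/C=C1\CCCc2cnn(Cc3ccc(Cl)cc3Cl)c21` gives 3 nM.
Compound 2 `O=C(NC/C=C1\CCCc2cnn(Cc3ccc(Cl)cc3Cl)c21)NS(=O)(=O)c1ccc(Cl)cc1` gives 4 nM.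
Compound 3 `Cc1nc(C)c(S(=O)(=O)NC(=O)NC/C=C2\CCCc3cnn(Cc4ccc(Cl)cc4Cl)c32)s1` gives 2 nM.

Compound 3 has the lowest of the three numbers, yet its gaps to compound 1 and to compound 2 both lie within the scatter. Compound 4 `COc1ccc(S(=O)(=O)NC(=O)NC/C=C2\CCCc3cnn(Cc4ccc(Cl)cc4Cl)c32)cc1` differs from compound 3 only in the group on the sulfonyl sulfur: 4-methoxyphenyl in place of 2,4-dimethyl-1,3-thiazol-5-yl on a sulfonyl sulfur. For the measured compounds named here, two measured steps bear on this position: a 1.5-fold lower number from compound 1 to compound 3 (0.18 log units; within the scatter) and a 2.0-fold lower number from compound 2 to compound 3 (0.30 log units; within the scatter). Both earlier swaps of the group on the sulfonyl sulfur stayed within the scatter, so for compound 4 no step beyond the scatter is expected in this assay. Compound 4 is therefore expected to give 3 nM, between 1.5 nM and 8 nM, an expected step of a 1.5-fold higher number from compound 3 to compound 4 (0.18 log units; within the scatter).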

Compound 4, inhibition constant: 10 nM
The estimate for compound 4 lay 3.3-fold (0.52 log units) below the measured number, and the stated range ends below it.
By their numbers in this assay, from the lowest: compounds 3, 1 and 2 (each within the scatter of the next); then compound 4.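

In this assay the group on the sulfonyl sulfur now moves the number beyond the scatter, as no earlier swap did, with a 5.0-fold higher number from compound 3 to compound 4 (0.70 log units; beyond the scatter) when 4-methoxyphenyl replaces 2,4-dimethyl-1,3-thiazol-5-yl. The two phenyl comparisons agree, with a 2.5-fold higher number from compound 2 to compound 4 (0.40 log units; beyond the scatter) for methoxy in place of chloro on an aromatic carbon and a 3.3-fold higher number from compound 1 to compound 4 (0.52 log units; beyond the scatter) for 4-methoxyphenyl in place of 5-chloro-2-methoxyphenyl, so this position does respond to the choice of group. No measurement shown here accounts for these steps. The compounds shown leave open whether methoxy itself drives the change, and how a 4-methylphenyl or 4-aminophenyl group on the sulfonyl sulfur would read.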